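Trifluoromethyl to Trifluoromethoxy: Expecting a Small Step

A few compounds are considered here, and "the series" means these few. Any claim that something is new, unique, unknown or untested is made for them only; others in the source may bear on it.

In a functional assay on T47D cells (Homo sapiens) for inhibition (on this read-out higher numbers stand for weaker inhibition and lower numbers for stronger inhibition), compound 1 `Oc1cccc(-c2cc(-c3cccc(F)c3)cc(-c3ccccc3O)n2)c1` gives > 50000 nM, which is the limit of > 50000 nM in this assay, at which 1 of the 2 values shown sits, rather than a measured number. Compound 2 `Oc1cccc(-c2cc(-c3ccccc3C(F)(F)F)cc(-c3ccccc3O)n2)c1` gives 5680 nM, the only true number shown, and an at least 8.8-fold lower number from compound 1 to compound 2 (0.94 log units; beyond the scatter). Compound 3 `Oc1cccc(-c2cc(-c3ccccc3OC(F)(F)F)cc(-c3ccccc3O)n2)c1` differs from compound 2 by trifluoromethoxy in place of trifluoromethyl on an aromatic carbon. The measured step replaced one whole aryl group with another, so it bears only loosely on this smaller exchange of a single substituent at the same place. Compound 3 is therefore expected to give about 6000 nM, between 2000 nM and 20000 nM. That estimate means an expected 1.1-fold higher number from compound 2 to compound 3 (0.02 log units; within the scatter), within the usual scatter.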

Compound 3, half-maximal inhibitory concentration: 2680 nM
Estimate against measurement, compound 3: 2.2-fold (0.35 log units) above; the measured number falls inside the stated range.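

Exchanging trifluoromethyl for trifluoromethoxy at this place, ortho to a large group, gives a 2.1-fold lower number from compound 2 to compound 3 (0.33 log units; beyond the scatter) in this assay. A single substituent at this place can therefore move the read-out, whereas the earlier step exchanged a whole aryl group. The two groups differ by one oxygen, counted as a hydrogen-bond acceptor, but nothing measured here tells why the number moves.

On these data alone, how an amine, a carboxylic acid or a longer chain would read at this place remains open. So does whether trifluoromethoxy would give a similar step elsewhere on the shared core.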